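Methyl on the Phenol Oxygen: From Compound 2 to Compound 4

This account rests on a few compounds, and the source may have more. Where it says the series, first, only, none or still open, it means among the compounds named here.

Of the compounds shown here, three built on one shared core have been measured in a functional assay on M14 cells (Homo sapiens) for inhibition, read by sulforhodamine B assay, with a stated time of 48 h, tested at 10 uM; on this read-out higher numbers stand for a weaker effect at the one concentration tested and lower numbers for a stronger effect. Compound 1 `O=C(Nc1cccc(-n2cc(-c3ccncc3)c(-c3cc(O)cc(Cl)c3)n2)c1)Nc1ccc(Cl)c(C(F)(F)F)c1` gives -16.8% in this assay, compound 2 `O=C(Nc1cccc(-n2cc(-c3ccncc3)c(-c3cc(O)cc(Cl)c3)n2)c1)Nc1ccc(Cl)c(Cl)c1` gives -69.2%, and compound 3 `COc1cc(Cl)cc(-c2nn(-c3cccc(NC(=O)Nc4cc(C(F)(F)F)cc(C(F)(F)F)c4)c3)cc2-c2ccncc2)c1` gives 1.22%. Compound 2 thus stands lowest of the three, with compound 1 as its nearest neighbour, higher by a gap beyond the scatter, and compound 3 furthest away. Among the compounds with values here, the only step between two compounds that differ in a single place is a number 52.4 percentage points lower from compound 1 to compound 2 (beyond the scatter), a change at a different part of the molecule than the one now in question.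

Compound 4 `COc1cc(Cl)cc(-c2nn(-c3cccc(NC(=O)Nc4ccc(Cl)c(Cl)c4)c3)cc2-c2ccncc2)c1` differs from compound 2 by methyl in place of hydrogen on an oxygen on an aromatic ring. Within the data shown here, no measured step concerns this change. Among the measured compounds shown here, compound 3 carries the methoxy and gives 1.22%, but it differs from compound 2 in more than one place, so it shows only that a methoxy-bearing compound can sit near zero. A weakening, that is a higher number, is expected, as the step of a number 39.2 percentage points higher from compound 2 to compound 4 (beyond the scatter), with wide uncertainty. Compound 4 is therefore estimated at -30%, within -75% to 10%.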

Compound 4, a percentage reported as activity, at one concentration (the size of the read-out at that concentration, not a potency): 18.7%
Compound 4: the middle estimate sits 48.7 percentage points below what was measured, and the stated range ends below it.
By their numbers in this assay, from the lowest: compound 2; then compound 1; then compound 3; then compound 4.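

Putting methyl in place of hydrogen on the oxygen of the 3-chloro-5-hydroxyphenyl group gives, in this assay, a number 87.9 percentage points higher from compound 2 to compound 4 (beyond the scatter), the first single-place step measured at this oxygen. It shows that this one change, which adds a single carbon, is enough to carry the read-out across zero: compound 2 gives -69.2% and compound 4 gives 18.7%, while everything else in compound 2 stays the same. Nothing measured here accounts for the size of this step.

On these data alone, it remains open whether hydroxy to methoxy would bring a step of similar size on compound 1, whose other ring carries trifluoromethyl. Also open, as far as these compounds go, is what a longer chain on this oxygen, such as ethyl, or an amine in place of the hydroxy would give.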